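Swapping a Nitrile for a Nitro Group on the Outer Ring

This account rests on a few compounds, and the source may have more. Where it says the series, first, only, none or still open, it means among the compounds named here.

Measured so far:
Compound 1, `COc1ccc(Cn2cc(CO/N=C/c3c(-c4ccc(C)cc4)nc4c(C)cccn34)nn2)cc1`, gives 100 mg/kg in a functional assay on the whole organism (strain NMRI) with Mus musculus as the target, with a stated time of 4 h; on this read-out lower numbers stand for an effect already at smaller amounts and higher numbers for an effect only at larger amounts of compound.
Compound 2, `Cc1ccc(-c2nc3c(C)cccn3c2/C=N/OCc2cn(Cc3ccc(C#N)cc3)nn2)cc1`, gives 100 mg/kg in this assay.

Among the compounds with values here, compound 2 stands level with compound 1, the only other measured compound: the step of no change at the digits printed from compound 1 to compound 2 (within the scatter) shows that exchanging one group for another on the outer ring left the read-out unchanged within the scatter.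

Compound 3, `Cc1ccc(-c2nc3c(C)cccn3c2/C=N/OCc2cn(Cc3ccc([N+](=O)[O-])cc3)nn2)cc1`, is not yet measured. It differs from compound 2 in one place: nitro in place of cyano on an aromatic carbon.

Within the data shown here, only one measured step bears on this change, the step of no change at the digits printed from compound 1 to compound 2 (within the scatter), which concerns the same place on the same ring and was without effect beyond the scatter. On that basis the expected step for compound 3 is no change at the digits printed from compound 2 to compound 3 (within the scatter), that is, no change beyond the scatter. The estimate for compound 3 is 100 mg/kg, with a range from 50 mg/kg to 200 mg/kg.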

Compound 3, minimum effective dose: 20 mg/kg
Compound 3: the middle estimate sits 5.0-fold (0.70 log units) above what was measured; measured number below the stated range.
By their numbers in this assay, from the lowest: compound 3; then compounds 1 and 2 (each within the scatter of the next).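

In this assay, nitro in place of cyano gives a 5.0-fold lower number from compound 2 to compound 3 (0.70 log units; beyond the scatter), and nitro in place of methoxy gives a 5.0-fold lower number from compound 1 to compound 3 (0.70 log units; beyond the scatter). The earlier pair alone could have suggested that the read-out does not respond to what sits on the outer ring para to the large group, but this place clearly can matter, since compound 3 acts at a smaller dose than either of the others. No available evidence bears on why nitro behaves differently here from cyano and methoxy.

As far as these compounds go, it remains open whether this drop in the number is particular to nitro or would also appear with another group at the same place, such as an amine or a carboxylic acid. From the compounds shown here alone, it is equally open whether nitro would give the same result elsewhere on this ring.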